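A few compounds are considered here, and "the series" means these few. Any claim that something is new, unique, unknown or untested is made for them only; others in the source may bear on it.

Measured so far:

Compound 1, `O=C1c2ccccc2C(=O)N1CCCCN1CCN(c2cccc3ccccc23)CC1`, in an assay on frontal cortex for binding affinity to Adrenergic receptor alpha-1 (Rattus norvegicus), read by radioligand binding (a lower number here means a stronger inhibitor, a higher number a weaker inhibitor), compound 1 gives 22 nM.
Compound 2, `COc1ccccc1N1CCN(CCCCNC(=O)c2ccc([N+](=O)[O-])cc2)CC1`, in this assay compound 2 gives 14 nM.

Both compounds carry a piperazine linked through a four-carbon chain to a nitrogen bearing a carbonyl, and differ in the aromatic group on the piperazine and in the group on the carbonyl side. The two numbers lie within the usual scatter of each other, so compound 2 stands alongside compound 1 without any real separation between them.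

Compound 3, `COc1ccccc1N1CCN(CCCCNC(=O)c2ccc(O)cc2)CC1`, has not yet been measured. It differs from compound 2 in one place: hydroxy in place of nitro on an aromatic carbon. Among the compounds with values here, no step between two measured compounds shows what this change does, so the expectation rests only on the position of compound 2. Since the change is confined to one group on the benzamide, the step from a 1.4-fold higher number from compound 2 to compound 3 (0.15 log units; within the scatter) is expected to be small, with no clear direction beyond the scatter. Compound 3 is therefore estimated at 20 nM, within a range from 7 nM to 60 nM.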

Compound 3, inhibition constant: 17 nM
Compound 3: the middle estimate sits 1.2-fold (0.07 log units) above what was measured, within the range that was stated.
By their numbers in this assay, from the lowest: compounds 2, 3 and 1 (each within the scatter of the next).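

In this assay, putting hydroxy in place of nitro, on the aromatic ring and para to a large group, gives a 1.2-fold higher number from compound 2 to compound 3 (0.08 log units; within the scatter). Within the data shown here, this is the first direct comparison at this position, and it does not separate the two groups, even though hydroxy has fewer heavy atoms than nitro and brings a hydrogen-bond donor that nitro lacks. Nothing shown here explains why the two compounds read alike.

Going by these compounds, a single exchange cannot show how much variation this position accepts, so it remains open whether an amine or a carboxylic acid in the same place would also stay within the scatter of compound 2. On these data alone, it is also open whether hydroxy and nitro would still read alike with a longer chain.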